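The compounds below may be only part of what the source reports. "The series", "measured", "known", "first", "only" and "open" are said of these compounds alone.

Compounds measured so far in a functional assay on MDA-MB-231 cells (Homo sapiens) for antiproliferative activity, read by MTT assay, with a stated time of 24 h; on this read-out lower numbers stand for stronger inhibition and higher numbers for weaker inhibition:
- compound 1 `O=C(NNc1ccc(F)cc1)c1cccc(NS(=O)(=O)c2cnc(O)nc2O)c1`: > 20000 nM (a limit)
- compound 2 `Cc1ccccc1C(=O)NNC(=O)c1cccc(NS(=O)(=O)c2cnc(O)nc2O)c1`: 18100 nM
- compound 3 `O=C(NNC(=O)c1ccccc1F)c1cccc(NS(=O)(=O)c2cnc(O)nc2O)c1`: > 20000 nM (a limit)

Compound 3 has no number of its own, only the limit > 20000 nM. It sits at the limit of > 20000 nM in this assay, at which 2 of the 3 values shown sit. The next compound, compound 4 `O=C(NNC(=O)c1cccc(NS(=O)(=O)c2cnc(O)nc2O)c1)c1ccc(F)cc1`, has the same atoms joined differently: 4-fluorophenyl in place of 2-fluorophenyl on a carbonyl carbon. In words, this is 4-fluorophenyl in place of 2-fluorophenyl on a carbonyl carbon.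

Within the data shown here, no measured step makes this exact change. The closest evidence is small: fluoro in place of methyl on an aromatic carbon gives an at least 1.1-fold higher number from compound 2 to compound 3 (0.04 log units; that floor lies within the scatter). The other change of this kind gives an at least 1.1-fold lower number from compound 1 to compound 2 (0.04 log units; that floor lies within the scatter), while the last gives a step that the two limits leave unreadable from compound 1 to compound 3. No step beyond the scatter is therefore expected in this assay, and compound 4 should stay near the top of the range. Among the measured compounds shown here, the only compound with a number, compound 2, gives 18100 nM, which supports that expectation. Compound 4 is expected at about 20000 nM. The estimated range for compound 4 runs from 11000 nM to 40000 nM. The expected size of the change is a number no higher from compound 3 to compound 4 (the limit leaves the size open).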

Compound 4, half-maximal inhibitory concentration: > 20000 nM
Compound 4 ended at the assay's limit (the forecaster's own chance of this, stated with the estimate: 60%); the middle value sits exactly at the limit.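

In this assay, 4-fluorophenyl in place of 2-fluorophenyl on a carbonyl carbon brings no number into view, and the steps from compound 3 to compound 4 and from compound 1 to compound 4 cannot be read, as both ends of each are limits. Among these compounds, the only step that can be read is an at least 1.1-fold higher number from compound 2 to compound 4 (0.04 log units; that floor lies within the scatter). No group shown on this carbonyl carbon, whether 2-methylphenyl, 2-fluorophenyl or 4-fluorophenyl, has given a readable step beyond the scatter, and the values gather at one point: the limit of > 20000 nM in this assay, at which 3 of the 4 values shown sit.

The compounds shown leave open whether an amine or a carboxylic acid on the phenyl ring, or a longer alkyl chain in its place, would give a value clearly under the limit. They also leave open how far past the limit compound 3 and compound 4 lie, and whether the two differ at all.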